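The source may hold more compounds than are shown below. What is called first, only, known or untested is meant among the compounds shown, and "the series" means these compounds.

Measured so far:
compound 1, `CCCn1c(=O)n(CCCOC)c(=O)c2[nH]cnc21`: 12400 nM
compound 2, `C=CCCn1cnc2c1c(=O)n(C)c(=O)n2CCC`: 6000 nM

Both compounds were tested in an assay on Cerebral cortex for binding affinity to adenosine receptor A1 (Cavia porcellus), read by radioligand binding; on this read-out higher numbers stand for weaker inhibition and lower numbers for stronger inhibition. Compound 1 gives 12400 nM, and compound 2 gives 6000 nM. Of these two numbers, compound 2 has the lower one, and the gap to compound 1 is wider than the usual scatter of repeated measurements, so compound 2 is the stronger inhibitor of the pair. Going by the values given here, no two compounds measured so far differ in just one place, so no single structural change has yet been followed by measurement in this assay.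

Compound 3, `CCCn1c(=O)n(C)c(=O)c2c1ncn2CC#N`, is still to be measured. It differs from compound 2 in one place: cyano in place of allyl on a saturated chain carbon bound to an aromatic nitrogen. Among the compounds with values here, no measured pair shows what this kind of change does here, so the expectation rests on compound 2 alone, whose number is the starting point. Only a small shift is expected, leaning slightly toward a higher number, and the step is estimated as a 1.3-fold higher number from compound 2 to compound 3 (0.12 log units; within the scatter). Compound 3 is therefore estimated at 8000 nM, within a range from 2500 nM to 25000 nM.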

Compound 3, inhibition constant: 6600 nM
Estimate against measurement, compound 3: 1.2-fold (0.08 log units) above, within the range that was stated.
By their numbers in this assay, from the lowest: compounds 2, 3 and 1 (each within the scatter of the next, the first and the last beyond it).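

Going by these compounds alone, this is the first single change that can be followed in this assay: cyano in place of allyl on a saturated chain carbon bound to an aromatic nitrogen gives a 1.1-fold higher number from compound 2 to compound 3 (0.04 log units; within the scatter), so the two compounds cannot be told apart on this read-out. The groups are not close copies of each other: allyl has 3 heavy atoms, a double bond and no hydrogen-bond acceptor, while cyano has 2 heavy atoms, a triple bond and 1 hydrogen-bond acceptor, yet this pair shows that these differences together leave the reading within the usual scatter. Why the two compounds read alike cannot be said from the information available.

The compounds shown leave open whether an amine, a carboxylic acid or a longer chain at this same place would also read like compound 2 and compound 3, or would move the number clearly. They also leave open whether cyano in place of allyl would read the same with other groups elsewhere on the shared core.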